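The source may report more compounds than this note shows. Statements on the series, on what has been measured and on what is new or still open speak of the compounds shown alone.

Values measured in a physicochemical assay for lipophilicity, using the shake flask method, at pH 7.4; a lower number here means a more polar compound, a higher number a more lipophilic compound:
- compound 1 `O=C(O)COc1ccc(NC(=O)COc2ccccc2)cc1F` gives -1.25
- compound 2 `Cc1cccc(OCC(=O)Nc2ccc(OCC(=O)O)c(F)c2)c1` gives -0.99
- compound 3 `CC(C)c1cccc(OCC(=O)Nc2ccc(OCC(=O)O)c(F)c2)c1` gives 0.15

Compound 3 stands highest of the three, and its gaps to the other two are a number 1.14 log units higher from compound 2 to compound 3 (beyond the scatter) and a number 1.40 log units higher from compound 1 to compound 3 (beyond the scatter). Compound 4 `CC(C)(C)c1cccc(OCC(=O)Nc2ccc(OCC(=O)O)c(F)c2)c1` differs from compound 3 in one place: methyl in place of hydrogen on a saturated chain carbon bound to an aromatic carbon and two saturated chain carbons. In words, this is methyl in place of hydrogen on a saturated chain carbon bound to an aromatic carbon and two saturated chain carbons, or isopropyl to tert-butyl. Within the data shown here, no measured step makes this exact change. The closest ones act on an aromatic carbon: a number 0.26 log units higher from compound 1 to compound 2 (within the scatter) for methyl in place of hydrogen, and a number 1.14 log units higher from compound 2 to compound 3 (beyond the scatter) for isopropyl in place of methyl. The first stayed small and the second was large, so a moderate rise in this assay is expected, smaller than the second. The expected size is a number 0.40 log units higher from compound 3 to compound 4 (beyond the scatter). Compound 4 is estimated at 0.55, with an expected range from 0.2 to 0.95.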

Compound 4, distribution coefficient: 0.35
For compound 4 the middle estimate is 0.20 log units above the measured one, within the range that was stated.
By their numbers in this assay, from the lowest: compounds 1 and 2 (each within the scatter of the next); then compounds 3 and 4 (each within the scatter of the next).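

In this assay, the methyl that turns isopropyl into tert-butyl, placed on a saturated chain carbon bound to an aromatic carbon and two saturated chain carbons, gives a number 0.20 log units higher from compound 3 to compound 4 (within the scatter) and so does not separate compound 4 from compound 3 beyond the scatter. Both larger replacements at the aromatic carbon remain large, with tert-butyl in place of methyl giving a number 1.34 log units higher from compound 2 to compound 4 (beyond the scatter) and tert-butyl in place of hydrogen giving a number 1.60 log units higher from compound 1 to compound 4 (beyond the scatter), so the large gain seen with isopropyl is kept but not clearly extended. Nothing at hand explains this reading.

As far as these compounds go, it remains open how a longer unbranched chain such as n-propyl would read in this assay in place of the tert-butyl. The same question applies to a cyclopropyl, a methoxy or an amine there.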